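This account rests on a few compounds, and the source may have more. Where it says the series, first, only, none or still open, it means among the compounds named here.

In a functional assay (mast cells) for inhibition, with Rattus norvegicus as the target (on this read-out higher numbers stand for an effect only at larger amounts of compound and lower numbers for an effect already at smaller amounts), compound 1 `CC1CC/C(=N\Nc2ccccc2F)c2ncc(C(=O)O)c(=O)n21` gives 1200 nM, compound 2 `CC1CC/C(=N\Nc2cccc(Br)c2)c2ncc(C(=O)O)c(=O)n21` gives 6700 nM and compound 3 `CC1CC/C(=N\Nc2ccccc2O)c2ncc(C(=O)O)c(=O)n21` gives 208000 nM, the highest number of the three. The change to compound 4 `COc1ccc(N/N=C2\CCC(C)n3c2ncc(C(=O)O)c3=O)cc1`, not yet measured, is 4-methoxyphenyl in place of 2-hydroxyphenyl on an amine nitrogen. For the measured compounds named here, two measured steps bear most directly on it, since both end at the 2-hydroxyphenyl compound: a 170-fold higher number from compound 1 to compound 3 (2.24 log units; beyond the scatter) and a 31-fold higher number from compound 2 to compound 3 (1.49 log units; beyond the scatter), both large and beyond the scatter. The remaining step, a 5.6-fold higher number from compound 1 to compound 2 (0.75 log units; beyond the scatter), is modest but also beyond the scatter, so the aryl group matters even without a hydroxy group. Going by the values given here, no measured compound carries a methoxy group, so the 4-methoxyphenyl group itself is untested. With the 2-hydroxyphenyl group gone, a large move to a lower number is expected, on the strength of a 31-fold higher number from compound 2 to compound 3 (1.49 log units; beyond the scatter), though probably not the full reach of a 170-fold higher number from compound 1 to compound 3 (2.24 log units; beyond the scatter). The expected step is a 17-fold lower number from compound 3 to compound 4 (1.24 log units; beyond the scatter). For compound 4 the estimate is 12000 nM, with an expected range of 2500 nM to 60000 nM.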

Compound 4, half-maximal effective concentration: 128000 nM
For compound 4 the middle estimate is 11-fold (1.03 log units) below the measured one; measured number outside the range, above it.
By their numbers in this assay, from the lowest: compound 1; then compound 2; then compounds 4 and 3 (each within the scatter of the next).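

In this assay the step of a 1.6-fold lower number from compound 3 to compound 4 (0.21 log units; within the scatter) shows that the 2-hydroxyphenyl group is not alone at the high end of the series: the 4-methoxyphenyl group, with no hydrogen-bond donor, stands level with it. The gap to the halogen-bearing aryl groups stays large, with a 19-fold higher number from compound 2 to compound 4 (1.28 log units; beyond the scatter) and a 110-fold higher number from compound 1 to compound 4 (2.03 log units; beyond the scatter) as the two measures of it. At this amine nitrogen, then, a large gap from compounds 1 and 2 does not depend on the hydroxy group, since the methoxy compound shows one too.

Open, going by these compounds, is whether a 2-methoxyphenyl or a 4-bromophenyl group on this nitrogen would follow its substituent or its ring position. No evidence on hand speaks to why these aryl groups separate as they do.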